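Swapping the aryl amide for a dimethylaminopropyl chain

The compounds below may be only part of what the source reports. "The series", "measured", "known", "first", "only" and "open" are said of these compounds alone.

Compound 1 `O=C(CCC(=O)OCCCCCCSc1ccc([N+](=O)[O-])c2nonc12)Nc1ccccc1F` carries a 2-fluorophenyl group on the amide-type nitrogen. In an assay on isolated protein for inhibition of glutathione S-transferase Mu 2 (Homo sapiens), with a stated time of 10 min (on this read-out higher numbers stand for weaker inhibition and lower numbers for stronger inhibition), compound 1 gives 350 nM, the second highest of the three numbers recorded. Compound 2 `O=C(CCC(=O)OCCCCCCSc1ccc([N+](=O)[O-])c2nonc12)Nc1cccc(Cl)c1` gives 1100 nM, and a 3.1-fold higher number from compound 1 to compound 2 (0.50 log units; beyond the scatter). Compound 3 `O=C(CCC(=O)OCCCCCCSc1ccc([N+](=O)[O-])c2nonc12)Nc1ccc(C(F)(F)F)cc1` gives 90 nM, and a 3.9-fold lower number from compound 1 to compound 3 (0.59 log units; beyond the scatter); a 12-fold lower number from compound 2 to compound 3 (1.09 log units; beyond the scatter).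

Compound 4 `CN(C)CCCNC(=O)CCC(=O)OCCCCCCSc1ccc([N+](=O)[O-])c2nonc12` differs from compound 1 in one place: 3-(dimethylamino)propyl in place of 2-fluorophenyl on an amide-type nitrogen. For the measured compounds named here, none of the measured steps replaces the aryl group with a chain; they only move a substituent around a phenyl ring and show that this assay responds to such changes by modest to large steps in either direction. Nothing here speaks directly to an open chain on the amide-type nitrogen, so the direction of the step is uncertain and the expectation is broad. Compound 4 is therefore expected to give 800 nM, within a range of 150 nM to 5000 nM, which corresponds to an expected 2.3-fold higher number from compound 1 to compound 4 (0.36 log units; beyond the scatter).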

Compound 4, half-maximal inhibitory concentration: 90 nM
Estimate against measurement, compound 4: 8.9-fold (0.95 log units) above; measured number below the stated range.
By their numbers in this assay, from the lowest: compounds 3 and 4 (each within the scatter of the next); then compound 1; then compound 2.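

The earlier compounds shown here all kept a phenyl ring on the amide-type nitrogen, whereas compound 4 has an open 3-(dimethylamino)propyl chain with no ring, and this assay shows a 3.9-fold lower number from compound 1 to compound 4 (0.59 log units; beyond the scatter) and a 12-fold lower number from compound 2 to compound 4 (1.09 log units; beyond the scatter) for this change. Set against the 4-(trifluoromethyl)phenyl group, the chain gives no change at the digits printed from compound 3 to compound 4 (within the scatter), so a phenyl ring on this nitrogen is not needed to reach the lowest number seen in these four compounds. No evidence at hand explains why the chain gives this result.

The compounds shown do not separate the dimethylamino group from the propyl chain that carries it, so a plain alkyl chain, a primary amine, a carboxylic acid or a longer chain on this nitrogen remains an open case. They also leave open whether the chain would give a similar number with changes elsewhere on the shared core.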